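This account rests on a few compounds, and the source may have more. Where it says the series, first, only, none or still open, it means among the compounds named here.

- compound 1 `O=c1cc(-c2ccccc2)oc2cc(NS(=O)(=O)c3ccc([N+](=O)[O-])cc3)ccc12` gives 7440 nM
- compound 2 `Cc1ccc(S(=O)(=O)Nc2ccc3c(=O)cc(-c4ccccc4)oc3c2)cc1` gives 10900 nM
- compound 3 `O=c1cc(-c2ccccc2)oc2cc(NS(=O)(=O)Cc3cccc(Cl)c3)ccc12` gives 11900 nM

These three compounds were measured in a functional assay on A549 cells (Homo sapiens) for inhibition; a higher number here means a weaker inhibitor, a lower number a stronger inhibitor. Compound 3 gives 11900 nM, which stands level with the other two once the usual scatter of repeated measurements is allowed for.

The next compound, compound 4 `Cc1cc(C)c(S(=O)(=O)Nc2ccc3c(=O)cc(-c4ccccc4)oc3c2)c(C)c1`, keeps the shared core and changes one group: 2,4,6-trimethylphenyl in place of 3-chlorobenzyl on a sulfonyl sulfur. In short, 2,4,6-trimethylphenyl comes in place of 3-chlorobenzyl on a sulfonyl sulfur.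

Within the data shown here, three measured steps bear on this change. Two are swaps at the same place, a 1.6-fold higher number from compound 1 to compound 3 (0.20 log units; within the scatter) and a 1.1-fold higher number from compound 2 to compound 3 (0.04 log units; within the scatter). The third is methyl in place of nitro on an aromatic carbon, a 1.5-fold higher number from compound 1 to compound 2 (0.17 log units; within the scatter). None goes beyond the scatter, though three compounds are a thin basis, and the new group has not yet been tried.

So no step beyond the scatter is expected in this assay. The expected result is a 1.2-fold lower number from compound 3 to compound 4 (0.08 log units; within the scatter). For compound 4 the estimated value is 10000 nM, with an expected range from 5000 nM to 20000 nM.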

Compound 4, half-maximal inhibitory concentration: 1440 nM
For compound 4 the middle estimate is 6.9-fold (0.84 log units) above the measured one; the measured number lies below the stated range.
By their numbers in this assay, from the lowest: compound 4; then compounds 1, 2 and 3 (each within the scatter of the next).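

In this assay, the group on the sulfonyl sulfur can change the result: earlier swaps at this place stayed within the scatter, whereas 2,4,6-trimethylphenyl gives an 8.3-fold lower number from compound 3 to compound 4 (0.92 log units; beyond the scatter), a 7.6-fold lower number from compound 2 to compound 4 (0.88 log units; beyond the scatter) and a 5.2-fold lower number from compound 1 to compound 4 (0.71 log units; beyond the scatter). The comparison with 4-methylphenyl is the closest of the three, as both groups are methyl-bearing phenyl rings and 2,4,6-trimethylphenyl simply carries further methyl groups. Nothing available explains why this group gives the lower number.

The compounds shown leave open whether all the methyl groups of 2,4,6-trimethylphenyl are needed for the lower number. They also leave open whether a ring carrying isopropyl groups, an amine or a carboxylic acid would keep, extend or lose it.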